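Para-methyl on the sulfonyl ring: from compound 3 to compound 4

The compounds below may be only part of what the source reports. "The series", "measured", "known", "first", "only" and "open" are said of these compounds alone.

Compound 1 `CCOc1ccc(Br)cc1C(C)NC(=O)N(C)S(=O)(=O)c1ccc(C)cc1`: 28600 nM
Compound 2 `Cc1ccc(S(=O)(=O)NC(=O)NC(C)c2cc(Br)ccc2OC(C)C)cc1`: 61800 nM
Compound 3 `CCOc1ccc(Br)cc1C(C)NC(=O)NS(=O)(=O)c1ccccc1`: > 300000 nM

Of the compounds shown here, three have been measured in a functional assay on thoracic aorta (Rattus norvegicus, strain Wistar), with a stated time of 15 min; a lower number here means that less compound is needed, a higher number that more compound is needed for the effect. Compound 1 gives 28600 nM in this assay. Compound 2, which carries the same 4-methylphenyl sulfonyl group but an isopropoxy in place of the ethoxy, gives 61800 nM. Compound 3 stands apart: its result of > 300000 nM is a limit of this assay and not a number, as the limit of > 300000 nM in this assay, at which 1 of the 3 values shown sits, records.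

The step from compound 3 to compound 4 `CCOc1ccc(Br)cc1C(C)NC(=O)NS(=O)(=O)c1ccc(C)cc1` is a single change, (methyl in place of hydrogen on an aromatic carbon). The measured compounds cannot give the size of this step directly, because compound 3 sits at the limit. Still, both compounds that carry the 4-methylphenyl group, compound 1 and compound 2, return numbers in this assay, while the phenyl analogue compound 3 does not. On that basis an account of compound 4 expects a step in the direction of less compound needed, larger than the scatter, and its size is estimated as an at least 6.6-fold lower number from compound 3 to compound 4 (0.82 log units; beyond the scatter). Compound 4 is therefore estimated at 45000 nM in this assay, within a range from 15000 nM to 150000 nM.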

Compound 4, half-maximal effective concentration: > 300000 nM
Compound 4: only a limit was reported (the forecaster's own chance of this, stated with the estimate: 15%); middle value at least 6.6-fold (0.82 log units) away from the limit.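

Compound 4, like compound 3, ends at a limit of this assay and not at a number, so the step between them cannot be read: the limit of > 300000 nM in this assay, at which 2 of the 4 values shown sit.

The 4-methylphenyl group on its own therefore does not bring this core to a readable number in this assay, and the position on the sulfonyl ring cannot carry the result of compound 1 or compound 2 by itself. What separates compound 4 from those two lies elsewhere: hydrogen in place of methyl on the amide-type nitrogen gives an at least 10-fold higher number from compound 1 to compound 4 (1.02 log units; beyond the scatter), and hydrogen in place of methyl on the saturated chain carbon of the alkoxy group gives an at least 4.8-fold higher number from compound 2 to compound 4 (0.68 log units; beyond the scatter).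

On these data alone, with both compound 3 and compound 4 at the limit, it stays open whether the methyl on the sulfonyl ring has any effect at all on this core. The compounds shown also leave open how an ethyl on the amide-type nitrogen, or a longer chain such as butoxy in place of the ethoxy, would read in this assay.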